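The source may hold more compounds than are shown below. What is called first, only, known or untested is meant among the compounds shown, and "the series" means these compounds.

Two amides built on the same long-chained core have been tested in a functional assay on MKN-45 cells (Homo sapiens) for inhibition, read by colorimetric assay and sulforhodamine B assay, with a stated time of 48 h; on this read-out higher numbers stand for weaker inhibition of growth and lower numbers for stronger inhibition of growth. There, compound 1, `CCCCCCCCCCCC[C@@H](O)[C@H]1CC[C@H]([C@H](O)CCCCCCCCCCNC(=O)c2cccs2)O1`, gives 3310 nM, and compound 2, `CCCCCCCCCCCC[C@@H](O)[C@H]1CC[C@H]([C@H](O)CCCCCCCCCCNC(=O)c2ccsc2)O1`, gives 3720 nM. Compound 2 therefore stands level with compound 1, since a 1.1-fold higher number from compound 1 to compound 2 (0.05 log units; within the scatter) replaces thiophen-2-yl with thiophen-3-yl on a carbonyl carbon and stays within the scatter.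

Compound 3, `CCCCCCCCCCCC[C@@H](O)[C@H]1CC[C@H]([C@H](O)CCCCCCCCCCNC(=O)c2ccnn2C)O1`, has yet to be measured in this assay. It keeps the core of compound 2 and changes only the group on the carbonyl carbon: 1-methyl-1H-pyrazol-5-yl in place of thiophen-3-yl on a carbonyl carbon. Within the data shown here, this is a larger change than the one between the measured compounds, as the ring itself now carries different hetero atoms and a methyl group. Among the measured compounds shown here, that single measured step is the only guide, and it shows just that one swap of five-membered aromatic rings left the number unmoved. For the measured compounds named here, no measured compound carries 1-methyl-1H-pyrazol-5-yl, so the direction remains uncertain.

No shift beyond the scatter is expected, and the estimated change is a 1.3-fold higher number from compound 2 to compound 3 (0.13 log units; within the scatter). For compound 3 the expected value is 5000 nM, with an estimated range from 2000 nM to 12000 nM.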

Compound 3, concentration for 50% growth inhibition: 7410 nM
Estimate against measurement, compound 3: 1.5-fold (0.17 log units) below; low and high end bracket the measured number.
By their numbers in this assay, from the lowest: compounds 1, 2 and 3 (each within the scatter of the next, the first and the last beyond it).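

Among these compounds, until now, the only change at this carbonyl carbon was the point of attachment of a thiophene, so compound 3 is the first to carry a ring with different hetero atoms, and a methyl group as well. In this assay, among the compounds shown here, the replacement of thiophen-3-yl by 1-methyl-1H-pyrazol-5-yl gives a 2.0-fold higher number from compound 2 to compound 3 (0.30 log units; within the scatter) while the replacement of thiophen-2-yl gives a 2.2-fold higher number from compound 1 to compound 3 (0.35 log units; beyond the scatter) so the same new group falls on either side of the scatter depending on which thiophene serves as the reference, and the one step beyond it is modest. Nothing measured here explains this shift.

Which part of the change matters, the ring nitrogens or the methyl group, stays open, and a pyrazol-5-yl ring without the methyl would help to separate the two. Also open, as far as these compounds go, is how a six-membered ring such as phenyl or pyridinyl, or a simple open chain such as ethyl in place of the ring, would read on this carbonyl carbon.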